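Ring-bearing amine in place of dimethylamino on the shared core

This account rests on a few compounds, and the source may have more. Where it says the series, first, only, none or still open, it means among the compounds named here.

Compound 1, with structure `CN(C)c1ccc(C#CC(C)(O)c2nccs2)cc1Nc1ncnc2[nH]ccc12`, carries a dimethylamino group on an aromatic carbon of the shared core. Going by the values given here, in an assay for inhibition of mitogen-activated protein kinase kinase kinase 14 (Homo sapiens), read by luminescence and ADP-Glo, with a stated time of 120 min, in the presence of a further agent that is not named here (on this read-out lower numbers stand for stronger inhibition and higher numbers for weaker inhibition), compound 1 gives 22.5 nM, the lowest of the two numbers measured so far. Its nearest neighbour is compound 2, structure `CC(O)(C#Cc1ccc(N2CCNCC2)c(Nc2ncnc3[nH]ccc23)c1)c1nccs1`, which in this assay gives 47.9 nM. Among the compounds with values here, the one change between them, piperazin-1-yl in place of dimethylamino on an aromatic carbon, brought a 2.1-fold higher number from compound 1 to compound 2 (0.33 log units; beyond the scatter).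

Compound 3, structure `CN1CCCN(c2ccc(C#CC(C)(O)c3nccs3)cc2Nc2ncnc3[nH]ccc23)CC1`, has not yet been measured. It differs from compound 1 as follows: 4-methyl-1,4-diazepan-1-yl in place of dimethylamino on an aromatic carbon. Within the data shown here, the only measured step that resembles this change is the swap of dimethylamino for a ring-bearing amine, seen as a 2.1-fold higher number from compound 1 to compound 2 (0.33 log units; beyond the scatter), a modest weakening. Since the entering group here is again a nitrogen-containing ring put in the same place, a weakening of similar, modest size is expected, though a ring of a different size and with a methyl group leaves the outcome uncertain.

Compound 3 is therefore estimated to give about 42 nM in this assay, within a range of 15 nM to 120 nM, corresponding to an expected step of a 1.9-fold higher number from compound 1 to compound 3 (0.27 log units; within the scatter).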

Compound 3, half-maximal inhibitory concentration: 60.1 nM
For compound 3 the middle estimate is 1.4-fold (0.16 log units) below the measured one; the measured number falls inside the stated range.
By their numbers in this assay, from the lowest: compound 1; then compounds 2 and 3 (each within the scatter of the next).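

In this assay, a second ring-bearing amine on this aromatic carbon, 4-methyl-1,4-diazepan-1-yl in place of dimethylamino, brought a 2.7-fold higher number from compound 1 to compound 3 (0.43 log units; beyond the scatter), so among the compounds shown, both swaps away from the small open-chain dimethylamino group raise the number by a modest step beyond the scatter. Exchanging the six-membered piperazin-1-yl for the methylated seven-membered ring brought only a 1.3-fold higher number from compound 2 to compound 3 (0.10 log units; within the scatter), which means that this assay does not separate these two ring-bearing amines, even though the ring size, the methyl group and the ring's outer nitrogen all differ between them. No measurement shown here offers an explanation for any of these steps.

Compound 2 and compound 3 differ in both ring size and methylation. These compounds leave the separate contribution of each feature open, and 4-methylpiperazin-1-yl would be the natural group for pulling the two apart. As far as these compounds go, it also remains open whether the second ring nitrogen matters at all, a question that a piperidin-1-yl or morpholin-4-yl ring at the same place could address.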